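A few compounds are considered here, and "the series" means these few. Any claim that something is new, unique, unknown or untested is made for them only; others in the source may bear on it.

Compound 1 `CC1=CCCC(C)(C)C1/C=C/C(=O)/C=C/c1cccc(C(F)(F)F)c1` gives 2900 nM in a functional assay on CWR22R cells (Homo sapiens) for cytotoxicity, read by MTT assay, with a stated time of 72 h; on this read-out higher numbers stand for weaker inhibition and lower numbers for stronger inhibition.
Compound 2 `CC1=CCCC(C)(C)C1/C=C/C(=O)/C=C/c1ccc(C(F)(F)F)cc1` gives 3300 nM in this assay.
Compound 3 `CC1=CCCC(C)(C)C1/C=C/C(=O)/C=C/c1cc(C(F)(F)F)ccc1F` gives 3500 nM in this assay.

Compound 1 has the lowest of these three numbers, yet all three lie within the usual scatter of one another, so no ranking among them can be drawn. Going by the values given here, the only step between neighbours that differ in one place, a 1.2-fold higher number from compound 1 to compound 3 (0.08 log units; within the scatter), is also within the scatter. Compound 4 `CC1=CCCC(C)(C)C1/C=C/C(=O)/C=C/c1cccc(C)c1` differs from compound 1 by methyl in place of trifluoromethyl on an aromatic carbon. Among the compounds with values here, no measured pair swaps these two groups, and the one change already examined on this aromatic ring left the number essentially where it was, so no step beyond the scatter in this assay is expected here either. Compound 4 is therefore estimated at 3200 nM in this assay, with a range of 1500 nM to 7000 nM. That estimate means an expected 1.1-fold higher number from compound 1 to compound 4 (0.04 log units; within the scatter).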

Compound 4, half-maximal inhibitory concentration: 15200 nM
For compound 4 the middle estimate is 4.8-fold (0.68 log units) below the measured one; measured number outside the range, above it.
By their numbers in this assay, from the lowest: compounds 1, 2 and 3 (each within the scatter of the next); then compound 4.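

Unlike the earlier fluoro change on this ring, which stayed within the scatter, methyl in place of trifluoromethyl at this position does register: in this assay it gives a 5.2-fold higher number from compound 1 to compound 4 (0.72 log units; beyond the scatter) and so shows that the group on this aromatic carbon matters. In this pair, trifluoromethyl goes with the lower number, meaning stronger inhibition. Nothing measured here explains the difference.

Going by these compounds, whether an amine or a carboxylic acid here would sit nearer compound 1 or compound 4 stays open. So does whether the same swap in compound 2 would give a step of similar size.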